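Hydroxyethyl extension of one alkyne in the diyne series

This account rests on a few compounds, and the source may have more. Where it says the series, first, only, none or still open, it means among the compounds named here.

The series is tested in a functional assay on A549 cells (Homo sapiens) for cytotoxicity, read by resazurin assay, with a stated time of 72 h; on this read-out lower numbers stand for stronger inhibition and higher numbers for weaker inhibition. Compound 1 `OCC#Cc1nccn1C#CCO` gives 1900 nM. Compound 2 `C#Cc1nc(-c2ccccc2)cn1C#C` gives 2500 nM, and compound 3 `C#Cc1nc(-c2ccc(F)cc2)cn1C#C` gives 2600 nM. For the measured compounds named here, the only single-point step measured so far, a 1.0-fold higher number from compound 2 to compound 3 (0.02 log units; within the scatter), concerns a fluoro in place of hydrogen on an aromatic carbon and is flat. Compound 3 carries the largest number of the three, but its gap to compound 2 and its gap to compound 1 are both within the scatter, so no ranking among the three follows.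

Compound 4 `C#Cn1cc(-c2ccc(F)cc2)nc1C#CCCO` differs from compound 3 by 2-hydroxyethyl in place of hydrogen on a triple-bonded carbon. Going by the values given here, no measured step bears directly on this change: the one step available alters the aromatic ring, not a triple-bonded carbon, and compound 1, which carries hydroxymethyl on both alkynes, is not connected to compound 3 by a single change. With the measured step from compound 2 to compound 3 being within the scatter and nothing else to draw on, the step in this assay from compound 3 to compound 4 is expected to be a 1.1-fold lower number from compound 3 to compound 4 (0.03 log units; within the scatter), that is, none beyond the scatter. Compound 4 is therefore estimated at 2400 nM, within 1100 nM to 5200 nM.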

Compound 4, half-maximal inhibitory concentration: 2600 nM
The estimate for compound 4 lay 1.1-fold (0.03 log units) below the measured number; measured number inside the range.
By their numbers in this assay, from the lowest: compounds 1, 2, 3 and 4 (each within the scatter of the next).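

In this assay, 2-hydroxyethyl in place of hydrogen on a triple-bonded carbon gives no change at the digits printed from compound 3 to compound 4 (within the scatter), the only measured step at this position in the compounds shown. Where the earlier step concerned the aromatic ring, this one changes the alkyne itself, and it shows that in this pair ethynyl can give way to 4-hydroxybut-1-yn-1-yl with the number staying within the scatter. Nothing measured here accounts for this flat step.

Still open, from the compounds shown here alone, is whether the same flat step holds at the other alkyne of the shared core, or on compound 2, which lacks the fluoro group. Also open, going by these compounds, is how this triple-bonded carbon responds to other ends on the chain, such as a primary amine or a carboxylic acid in place of the hydroxyl, or to a longer chain ending in hydroxyl, and whether any of these moves the number beyond the scatter.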